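The compounds below may be only part of what the source reports. "The series", "measured", "known", "first", "only" and "open" are said of these compounds alone.

Of the compounds shown here, three with a shared core have been tested in an assay on SH-SY5Y cells for inhibition of Voltage-dependent L-type calcium channel subunit alpha-1D (Homo sapiens), read by calcium flux, with a stated time of 15 min; a higher number here means a weaker inhibitor, a lower number a stronger inhibitor. Compound 1 `CCOC(=O)C1=C(C)NC(c2ccccc2)=CC1c1ccccc1` gives 18700 nM. Compound 2 `CC1=C(C(=O)SC(C)(C)C)C(c2ccccc2)C=C(c2ccccc2)N1` gives 95800 nM, while compound 3 `CC1=C(C(=O)SC(C)(C)C)C(c2ccc(C)cc2)C=C(c2ccccc2)N1` gives 56200 nM. Compound 2 and compound 3 differ by methyl in place of hydrogen on an aromatic carbon, a change that produced a 1.7-fold lower number from compound 2 to compound 3 (0.23 log units; within the scatter). Compound 2 and compound 1 differ by ethoxy in place of (tert-butyl)sulfanyl on a carbonyl carbon, a change that produced a 5.1-fold lower number from compound 2 to compound 1 (0.71 log units; beyond the scatter).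

Compound 4 `CCOC(=O)C1=C(C)NC(c2ccccc2)=CC1c1ccc(C)cc1` has not yet been measured. It differs from compound 3 by ethoxy in place of (tert-butyl)sulfanyl on a carbonyl carbon, the same change as from compound 2 to compound 1, at a place described in identical words. For compound 4 a step of a 5.1-fold lower number from compound 3 to compound 4 (0.71 log units; beyond the scatter) in this assay is expected. That expectation rests on compound 2, because a 5.1-fold lower number from compound 2 to compound 1 (0.71 log units; beyond the scatter) was observed for the same change. Compound 4 is therefore estimated at 11000 nM, with a likely range from 4000 nM to 30000 nM.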

Compound 4, half-maximal inhibitory concentration: 20600 nM
Compound 4: the middle estimate sits 1.9-fold (0.27 log units) below what was measured; the measured number falls inside the stated range.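

Ethoxy in place of (tert-butyl)sulfanyl on a carbonyl carbon gives a 2.7-fold lower number from compound 3 to compound 4 (0.44 log units; beyond the scatter) in this assay, so this change points the same way on both cores, and the two steps agree in size: the same change on two cores in this assay, a 5.1-fold lower number (0.71 log units; beyond the scatter) from compound 2 to compound 1 and a 2.7-fold lower number (0.44 log units; beyond the scatter) from compound 3 to compound 4, 1.9-fold (0.27 log units) apart, within the scatter of two such steps. Methyl in place of hydrogen on an aromatic carbon gives a 1.1-fold higher number from compound 1 to compound 4 (0.04 log units; within the scatter), and neither step for that change stands clear of the scatter: the same change on two cores in this assay, a 1.7-fold lower number (0.23 log units; within the scatter) from compound 2 to compound 3 and a 1.1-fold higher number (0.04 log units; within the scatter) from compound 1 to compound 4, 1.9-fold (0.27 log units) apart, within the scatter of two such steps. For the compounds shown here, each change has been seen on only two cores, so this shows agreement within this small set and does not show that either change would carry to other cores.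

The compounds shown leave open how a longer chain in place of ethoxy would read. They also leave open what a chlorine or an amine in place of the methyl would do.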